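The compounds below may be only part of what the source reports. "The series", "measured", "known", "first", "only" and "open" are said of these compounds alone.

The measured compounds and their values:
compound 1, `COc1cc2cc(Oc3ccc(NC(=O)Nc4ccc(C)cc4)cc3)c(C)nc2cc1OC`, 107%;
compound 2, `COc1cc2cc(Oc3ccc(NC(=O)Nc4ccc(C(F)(F)F)cc4)cc3)c(C)nc2cc1OC`, 56%;
compound 3, `COc1cc2cc(Oc3ccc(NC(=O)Nc4ccc(Cl)c(C(F)(F)F)c4)cc3)c(C)nc2cc1OC`, -70.9%.

In a functional assay on SF-295 cells (Homo sapiens) for inhibition, read by sulforhodamine B assay, with a stated time of 48 h, tested at 10 uM (on this read-out higher numbers stand for a weaker effect at the one concentration tested and lower numbers for a stronger effect), compound 2 stands second highest of the three numbers: compound 1 lies higher (a number 51 percentage points lower from compound 1 to compound 2 (beyond the scatter)) and compound 3 lies far lower (a number 126.9 percentage points lower from compound 2 to compound 3 (beyond the scatter)). Compound 4, `COc1cc2cc(Oc3ccc(NC(=O)Nc4ccc(Cl)c(Cl)c4)cc3)c(C)nc2cc1OC`, has not been measured in this assay. Its difference from compound 2 is 3,4-dichlorophenyl in place of 4-(trifluoromethyl)phenyl on an amide-type nitrogen. Both steps that end at compound 3 bear on this change, a number 177.9 percentage points lower from compound 1 to compound 3 (beyond the scatter) and a number 126.9 percentage points lower from compound 2 to compound 3 (beyond the scatter), and both are large drops. Within the data shown here, a substantial drop beyond the scatter is therefore expected in this assay, though smaller than the one to compound 3, as compound 4 is not compound 3. Compound 4 is expected to give 0%, between -70% and 60%, an expected step of a number 56 percentage points lower from compound 2 to compound 4 (beyond the scatter).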

Compound 4, a percentage reported as activity, at one concentration (the size of the read-out at that concentration, not a potency): 0.69%
Compound 4: the middle estimate sits 0.7 percentage points below what was measured; measured number inside the range.
By their numbers in this assay, from the lowest: compound 3; then compound 4; then compound 2; then compound 1.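

In this assay, 3,4-dichlorophenyl on the amide-type nitrogen gives a number 55.3 percentage points lower from compound 2 to compound 4 (beyond the scatter) and a number 106.3 percentage points lower from compound 1 to compound 4 (beyond the scatter), so a large drop at this position does not require a trifluoromethyl group. Yet chloro in place of trifluoromethyl on an aromatic carbon gives a number 71.6 percentage points higher from compound 3 to compound 4 (beyond the scatter), so the two groups are not interchangeable on this ring. Nothing measured here explains these steps.

The compounds shown leave open how this ring would behave with an amine or a carboxylic acid in place of the chloro groups. They also leave open whether a single chloro group would give a similar drop.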